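Amino in Place of Chloro: An Expected Cytotoxicity Step

The source may hold more compounds than are shown below. What is called first, only, known or untested is meant among the compounds shown, and "the series" means these compounds.

Of the compounds shown here, two have so far been measured in a functional assay on SK-OV-3 cells (Homo sapiens) for cytotoxicity, read by sulforhodamine B assay, with a stated time of 48 h; a lower number here means that less compound is tolerated, a higher number that more compound is tolerated. Compound 1 `ClCc1ccccc1Cn1cnc2c(Cl)nc(Cl)nc21` gives 6910 nM, the lowest of the two numbers, so of these two it is the one of which the cells tolerate the least. Compound 2 `ClCc1cccc(Cn2cnc3c(Cl)ncnc32)c1` gives 33100 nM, a higher number that lies beyond the usual scatter. Going by the values given here, the two compounds differ from each other in more than one place, so no single step can be drawn between them.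

Compound 3 `Nc1nc(Cl)c2ncn(Cc3ccccc3CCl)c2n1` has not yet been measured. It differs from compound 1 in exactly one place: amino in place of chloro on an aromatic carbon. Among the compounds with values here, no pair of measured compounds shows a change of this kind, so the direction and size of the step have to be expected rather than read off. The expectation for compound 3 is that the cells tolerate somewhat more of it than of compound 1, a step of a 2.2-fold higher number from compound 1 to compound 3 (0.34 log units; beyond the scatter) that is modest but probably reaches beyond the scatter. In this assay compound 3 is therefore estimated at 15000 nM, with a range from 5000 nM to 45000 nM.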

Compound 3, concentration lethal to 50% of the cells: > 100000 nM
Compound 3 ended at the assay's limit (the forecaster's own chance of this, stated with the estimate: 10%); at least 6.6-fold (0.82 log units) between middle value and limit.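

In this assay, going by these compounds alone, amino in place of chloro on an aromatic carbon, between two ring nitrogen atoms, gives an at least 14-fold higher number from compound 1 to compound 3 (1.16 log units; beyond the scatter), the first step at this position that can be read, as the earlier pair differs in more than one place. The value of compound 3, > 100000 nM, is a limit of the assay and not a number: the limit of > 100000 nM in this assay, at which 1 of the 3 values shown sits. Within this single pair, the position between two ring nitrogen atoms is clearly not indifferent to what sits on it, and the change from chloro to amino carries the reading from a measured value to the limit, though one pair sets no rule for other compounds.

The compounds shown leave open how a methoxy group, a methylamino group or a dimethylamino group at this position would read, as amino is the only replacement for chloro among them. They also leave open what lies behind the step and where compound 3 would fall past the limit, and whether the same change would have a similar effect on the core of compound 2.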